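The source may hold more compounds than are shown below. What is called first, only, known or untested is meant among the compounds shown, and "the series" means these compounds.

Measured in a functional assay on SAOS-2 cells (Homo sapiens) for antiproliferative activity, read by MTT assay, with a stated time of 72 h; on this read-out lower numbers stand for stronger inhibition and higher numbers for weaker inhibition:

Compound 1 `O=C(C1=C(OC2CCCCC2)C(=O)N(CCCn2ccnc2)C1c1ccc(Br)cc1)c1ccccc1`: 29700 nM
Compound 2 `Cc1ccc(NC2=C(C(=O)c3ccccc3)C(c3ccc(Br)cc3)N(CCCn3ccnc3)C2=O)cc1`: 31900 nM
Compound 3 `O=C(C1=C(Nc2ccc(Cl)cc2)C(=O)N(CCCn2ccnc2)C1c1ccc(Br)cc1)c1ccccc1`: 24800 nM

Among these three numbers, compound 1 holds the second highest. Its nearest neighbour is compound 2, with a 1.1-fold higher number from compound 1 to compound 2 (0.03 log units; within the scatter), and its furthest is compound 3, with a 1.2-fold lower number from compound 1 to compound 3 (0.08 log units; within the scatter); both of these steps fall within the scatter, so the three compounds cannot be told apart in this assay.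

Compound 4 `O=C(C1=C(Nc2ccc(OC(F)(F)F)cc2)C(=O)N(CCCn2ccnc2)C1c1ccc(Br)cc1)c1ccccc1` has not yet been measured. It differs from compound 1 by (4-(trifluoromethoxy)phenyl)amino in place of cyclohexyloxy on a double-bonded ring carbon. The two measured steps that bear on this are those from compound 1 to compound 2 and from compound 1 to compound 3, in each of which cyclohexyloxy was likewise exchanged for an arylamino group on the same double-bonded ring carbon, and neither moved the number beyond the scatter. A step of about the same kind is therefore expected here: a 1.1-fold lower number from compound 1 to compound 4 (0.04 log units; within the scatter), that is, no change beyond the scatter. Compound 4 is accordingly estimated at 27000 nM, with a range from 13000 nM to 55000 nM.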

Compound 4, half-maximal inhibitory concentration: 17900 nM
Compound 4: the middle estimate sits 1.5-fold (0.18 log units) above what was measured, and the stated range covers the measured number.
By their numbers in this assay, from the lowest: compounds 4, 3, 1 and 2 (each within the scatter of the next).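

In this assay, the (4-(trifluoromethoxy)phenyl)amino group, which brings an aromatic ring and a hydrogen-bond donor that cyclohexyloxy lacks, still gives a 1.7-fold lower number from compound 1 to compound 4 (0.22 log units; within the scatter) at this double-bonded ring carbon. On the aromatic ring of the arylamino group, trifluoromethoxy joins chloro and methyl as a third substituent with no separable effect, giving a 1.4-fold lower number from compound 3 to compound 4 (0.14 log units; within the scatter) and a 1.8-fold lower number from compound 2 to compound 4 (0.25 log units; within the scatter), so all four compounds remain indistinguishable in this assay. Nothing available here accounts for how alike these groups are.

From the compounds shown here alone, it remains open whether a hydroxyl group, a carboxylic acid or a saturated amine such as morpholine at this ring carbon would move the number beyond the scatter. Going by these compounds, the contributions of the benzoyl, 4-bromophenyl and 3-(1H-imidazol-1-yl)propyl groups also stay unknown, since all four compounds share them.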